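A few compounds are considered here, and "the series" means these few. Any claim that something is new, unique, unknown or untested is made for them only; others in the source may bear on it.

In a functional assay on L02 cells (Homo sapiens) for inhibition, read by Griess assay, with stated times of 1 h and 24 h (a lower number here means a stronger inhibitor, a higher number a weaker inhibitor), the measured compounds all need high concentrations to register. Compound 1 `CCCc1nn(C)c2c(NC(C)C)nc(/C=C/c3nc(C)c(C)nc3C)nc12` gives 342000 nM, and compound 2 `CCCc1nn(C)c2c(NC3CC3)nc(CCc3cccnc3)nc12` gives 564000 nM. These two values lie within the usual scatter of each other. Compound 3 `CNc1nc(/C=C/c2ccccc2)nc2ccsc12` gives > 1000000 nM, which is a limit and not a number. It stands at the limit of > 1000000 nM in this assay, at which 1 of the 3 values shown sits.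

Compound 4 `CN1CCN(c2nc(/C=C/c3ccccc3)nc3ccsc23)CC1` keeps the rest of compound 3 but carries 4-methylpiperazin-1-yl in place of methylamino on an aromatic carbon. The counted change is 4-methylpiperazin-1-yl in place of methylamino on an aromatic carbon.

Among the measured compounds shown here, no two measured compounds differ in only one place, so the data show no direct effect of a change like this one. The expectation is therefore a modest step at most, with a slight lean toward stronger inhibition and a readable number, because compound 2 reads 564000 nM in this assay. This lean is weak, and compound 4 could just as well end up reported only as a limit. The expected change is an at least 1.3-fold lower number from compound 3 to compound 4 (0.12 log units; that floor lies within the scatter). Compound 4 is estimated at 750000 nM, with an expected range from 300000 nM to 1500000 nM.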

Compound 4, half-maximal inhibitory concentration: 198000 nM
Compound 4: the middle estimate sits 3.8-fold (0.58 log units) above what was measured; measured number below the stated range.
By their numbers in this assay, from the lowest: compounds 4, 1 and 2 (each within the scatter of the next, the first and the last beyond it). At a limit, above all of these: compound 3.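

In this assay, among the compounds shown here, a single change on an aromatic carbon next to the ring nitrogen gives an at least 5.0-fold lower number from compound 3 to compound 4 (0.70 log units; beyond the scatter), the first comparison here in which only one place differs. The position therefore tolerates 4-methylpiperazin-1-yl, with 7 heavy atoms and a six-membered non-aromatic ring against the 2 heavy atoms of methylamino, and the hydrogen-bond donor of methylamino is not required for a readable value, although compound 4 still needs a high concentration at 198000 nM. The true size of the step remains unknown, since compound 3 stands at a limit and not a number: the limit of > 1000000 nM in this assay, at which 1 of the 4 values shown sits.

This one change alters size, ring content and hydrogen-bond count together, so the data cannot say which of these accounts for the lower number. Morpholin-4-yl, piperidin-1-yl or an open-chain dimethylamino group on the same carbon would help separate the role of the ring from that of its second nitrogen, and it also remains open whether the same change would act alike on the cores of compound 1 and compound 2.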